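A few compounds are considered here, and "the series" means these few. Any claim that something is new, unique, unknown or untested is made for them only; others in the source may bear on it.

Working notes on the series. Compound 1 `COc1ccc(NC(=O)COc2cc(C)nc3ccc(OC)cc23)c(OC)c1` and compound 2 `COc1ccc2nc(C)cc(OCC(=O)Nc3ccc(C)cc3)c2c1` are both run in an ADME assay on HepG2 cells (Homo sapiens) for cytotoxicity, read by trypan blue exclusion, with a stated time of 48 h, in the presence of a further agent that is not named here; on this read-out lower numbers stand for higher toxicity in this test and higher numbers for lower toxicity in this test. For compound 1 the read-out of > 131000 nM is a limit of the assay and not a number. For compound 2 the read-out of > 149000 nM is likewise a limit. Within the data shown here, compound 3 `COc1ccccc1NC(=O)COc1cc(C)nc2ccccc12` gives in this assay a value of 43900 nM, the only number among the values shown, so compound 3 is the single measured point from which a step can be followed. Compound 4 `COc1ccccc1NC(=O)COc1cc(C)nc2ccc(Br)cc12` differs from compound 3 by bromo in place of hydrogen on an aromatic carbon. Among the measured compounds shown here, no step between two measured compounds exists against which this change could be gauged, so the direction rests on expectation alone. A small shift toward higher toxicity, close to the scatter, is expected, and the step from compound 3 to compound 4 is estimated as a 1.5-fold lower number from compound 3 to compound 4 (0.17 log units; within the scatter). Compound 4 is accordingly expected to give 30000 nM in this assay, within an estimated range of 10000 nM to 100000 nM.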

Compound 4, half-maximal cytotoxic concentration: > 125000 nM
Compound 4 ended at the assay's limit; the forecaster's own chance of this, stated with the estimate: 15%; middle value at least 4.1-fold (0.61 log units) away from the limit.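

For compound 4 the read-out is a limit of the assay and not a number: the limit of > 125000 nM in this assay, at which 1 of the 4 values shown sits. Among these compounds, the pair still gives the first step between two compounds that differ in one place: in this assay, bromo in place of hydrogen on an aromatic carbon, para to a fused ring, gives an at least 2.8-fold higher number from compound 3 to compound 4 (0.45 log units; beyond the scatter). From the compounds shown here alone, at this position, bromo therefore shifts the read-out toward lower toxicity in this test, and the true size of the step remains unknown, as only its lower bound can be read.

Going by these compounds, whether a different group at this position, such as chloro, an amine or a carboxylic acid, would shift the read-out in the same direction remains open. This single pair also cannot show whether bromo would have the same effect elsewhere on the shared core or with a different amide part.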